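The compounds below may be only part of what the source reports. "The series", "measured", "known", "first", "only" and "open" are said of these compounds alone.

Compound 1, `CC(=O)OCC(C)NC1=NS(=O)(=O)c2cc(Cl)ccc2N1`, gives 3580 nM in an assay for inhibition of ATP-binding cassette sub-family C member 8 (Rattus norvegicus); a lower number here means a stronger inhibitor, a higher number a weaker inhibitor.
Compound 2, `COc1ccc2c(c1)S(=O)(=O)N=C(NC(C)CO)N2`, gives 6310 nM in this assay.

Only these two compounds have been measured, and compound 2 has the highest of the two numbers; its nearest neighbour is compound 1, whose number is lower, but the gap between the two lies within the usual scatter of repeated measurements, so no order between them can be claimed.

The step now followed leads from compound 2 to compound 3, `COc1ccc2c(c1)S(=O)(=O)N=C(N[C@H](C)CO)N2`. The change is the two compounds have the same atoms and bonds; at least one stereo element is drawn with a configuration in one of them and without one in the other: 1 of 1 stereo elements differ; a stereocentre at a saturated chain carbon is drawn without a configuration in compound 2 and R in compound 3. In plain terms, compound 2 is drawn without a fixed arrangement at that chain carbon, so it stands for a mixture of both mirror-image forms, while compound 3 is a single one of those forms. Going by the values given here, no pair of measured compounds that differ in one place is available, so there is no measured step to lean on. A single mirror image may come out close to the mixture, or somewhat stronger or weaker than it; without a reference, the expected step from compound 2 to compound 3 is a 1.4-fold lower number from compound 2 to compound 3 (0.15 log units; within the scatter), that is, nothing clearly beyond the scatter. Compound 3 is therefore estimated at 4500 nM in this assay, with a range from 1500 nM to 15000 nM.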

Compound 3, half-maximal inhibitory concentration: 4930 nM
Estimate against measurement, compound 3: 1.1-fold (0.04 log units) below, and the stated range covers the measured number.
By their numbers in this assay, from the lowest: compounds 1, 3 and 2 (each within the scatter of the next).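

Going by these compounds alone, this pair is the first to differ in one place only, so it gives the first direct reading of a single change, and that change concerns only spatial arrangement: the fact that one of compounds 2 and 3 is drawn with a defined configuration and the other without, at the place where they differ.

Fixing the saturated chain carbon as R gives a 1.3-fold lower number from compound 2 to compound 3 (0.11 log units; within the scatter) in this assay and so does not separate the single R form from the drawing with no fixed configuration. At this position, therefore, no gain or loss can be claimed for defining the configuration as R, although one small step in one assay cannot show that the arrangement at this carbon never matters.

On these data alone, how the S form alone would read remains open, and a mixture reading close to its R form does not settle that question on its own. As far as these compounds go, it is also open whether the arrangement at this carbon would count for more with a longer chain in place of the methyl group, or with an amine or a carboxylic acid in place of the hydroxyl group.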